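Shortening the chain of compound 3

The compounds below may be only part of what the source reports. "The series", "measured", "known", "first", "only" and "open" are said of these compounds alone.

compound 1 `CCCCCCCCCCNC[C@@H]1OC[C@H](N)[C@@H]1O` gives 47800 nM
compound 2 `CCCCCCCCCCCCCCNC[C@@H]1OC[C@H](N)[C@H]1O` gives 20000 nM
compound 3 `CCCCCCCCCCCNC[C@@H]1OC[C@H](N)[C@H]1O` gives 9650 nM

In a functional assay on A549 cells (Homo sapiens) for antiproliferative activity, read by MTT assay, with a stated time of 72 h (a higher number here means a weaker inhibitor, a lower number a stronger inhibitor), compound 3 has the lowest of these three numbers, so it is the strongest inhibitor so far. Compound 4 `CCCCCCCCCCNC[C@@H]1OC[C@H](N)[C@H]1O` carries one change (hydrogen in place of methyl on a saturated chain carbon, ten or more bonds along the chain from an amine nitrogen): hydrogen in place of methyl on a saturated chain carbon, ten or more bonds along the chain from an amine nitrogen. Hydrogen in place of propyl at that kind of place gave a 2.1-fold lower number from compound 2 to compound 3 (0.32 log units; beyond the scatter) and is the one measured step bearing on this. It was modest, and with the smaller methyl leaving, no step beyond the scatter is expected in this assay in either direction. A single step cannot establish a trend, so the range stays wide. The estimate amounts to a 1.1-fold lower number from compound 3 to compound 4 (0.03 log units; within the scatter) as the expected step. Compound 4 is expected at 9000 nM with an estimated range of 4000 nM to 22000 nM for the measurement.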

Compound 4, half-maximal inhibitory concentration: > 128000 nM
Compound 4 gave a limit, no number (the forecaster's own chance of this, stated with the estimate: 3%); middle value at least 14-fold (1.15 log units) away from the limit.
By their numbers in this assay, from the lowest: compound 3; then compound 2; then compound 1. At a limit, above all of these: compound 4.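

Compound 4 gave no number in this assay, only a limit: the limit of > 128000 nM in this assay, at which 1 of the 4 values shown sits. Chain length at this place matters more sharply than the earlier compounds showed, since hydrogen in place of methyl gives an at least 13-fold higher number from compound 3 to compound 4 (1.12 log units; beyond the scatter), while hydrogen in place of butyl gives an at least 6.4-fold higher number from compound 2 to compound 4 (0.80 log units; beyond the scatter). The configuration at a saturated ring carbon also counts, with an at least 2.6-fold higher number from compound 1 to compound 4 (0.42 log units; beyond the scatter): the fact that compounds 1 and 4 differ only in the configuration as drawn.

Still open, from the compounds shown here alone, is how a chain of intermediate length, longer than that of compound 3 but shorter than that of compound 2, would behave. Also open, going by these compounds, is whether an amide in place of the amine would keep the activity of compound 3.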